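Aryl Swap on the Shared Core: What Compound 4 May Show

The compounds below may be only part of what the source reports. "The series", "measured", "known", "first", "only" and "open" are said of these compounds alone.

Compound 1 `COc1ccc(-c2cn3ccnc3c(-c3ccc4ncn(C5CCCCC5)c4c3)n2)cc1`: 91.7%
Compound 2 `c1ccc2c(-c3cn4ccnc4c(-c4ccc5ncn(C6CCCCC6)c5c4)n3)cccc2c1`: 6.92%
Compound 3 `c1csc(-c2cn3ccnc3c(-c3ccc4ncn(C5CCCCC5)c4c3)n2)c1`: 27.2%

In a functional assay on SR cells (Homo sapiens) for inhibition, read by sulforhodamine B assay, with a stated time of 48 h, tested at 10 uM (on this read-out lower numbers stand for less inhibition and higher numbers for more inhibition at the one concentration tested (going by the name of the read-out)), compound 2 stands lowest of the three values shown. The nearer gap is a number 20.3 percentage points higher from compound 2 to compound 3 (beyond the scatter), the wider one a number 84.8 percentage points lower from compound 1 to compound 2 (beyond the scatter), both beyond the scatter. Compound 4 `FC(F)(F)c1cccc(-c2cn3ccnc3c(-c3ccc4ncn(C5CCCCC5)c4c3)n2)c1` differs from compound 2 by 3-(trifluoromethyl)phenyl in place of naphthalen-1-yl on an aromatic carbon. Within the data shown here, both measured steps bear on this kind of aryl exchange: each changed the read-out well beyond the scatter, and the single six-membered ring in compound 1 gave the highest number of the set. A rise from compound 2 is therefore expected, of uncertain size. Compound 4 is estimated at 40%, ranging from 10% to 80%. For compound 4 this amounts to an expected step of a number 33.1 percentage points higher from compound 2 to compound 4 (beyond the scatter).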

Compound 4, a percentage reported as inhibition, at one concentration (the size of the read-out at that concentration, not a potency): 15.6%
Compound 4: the middle estimate sits 24.4 percentage points above what was measured, and the stated range covers the measured number.
By their numbers in this assay, from the lowest: compounds 2 and 4 (each within the scatter of the next); then compound 3; then compound 1.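

In this assay, a single six-membered aromatic ring is not enough for a high number at this position: replacing the two-ring naphthalen-1-yl with 3-(trifluoromethyl)phenyl gives a number 8.7 percentage points higher from compound 2 to compound 4 (within the scatter). The other two steps are a number 11.6 percentage points lower from compound 3 to compound 4 (beyond the scatter) and a number 76.1 percentage points lower from compound 1 to compound 4 (beyond the scatter), so among the compounds shown, only 4-methoxyphenyl gives a high number. No evidence is available to explain these differences. Compound 1 and compound 4 differ in both the substituent and its place on the phenyl ring, so the two cannot be separated. From the compounds shown here alone, whether a 4-aminophenyl or 4-hydroxyphenyl group would match 4-methoxyphenyl remains open.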